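Sulfonamide swap on the shared core: methyl to 4-fluorophenyl

This account rests on a few compounds, and the source may have more. Where it says the series, first, only, none or still open, it means among the compounds named here.

Compound 1 `CCOC(=O)c1cnc2ccc(-c3cnc(OC)c(NS(C)(=O)=O)c3)cn12` carries a methanesulfonamido group and in a functional assay on A549 cells (Homo sapiens) for antiproliferative activity, read by sulforhodamine B assay, with a stated time of 72 h (a lower number here means a stronger inhibitor, a higher number a weaker inhibitor), gives 230 nM, the lower of the two numbers measured. Compound 2 `COc1ncc(-c2ccc3ncc(C(=O)NCc4ccncc4)n3c2)cc1NS(=O)(=O)c1ccc(F)cc1F`, with an arylsulfonamide on a different core, gives 500 nM in this assay, a gap beyond the scatter. Compound 3 `CCOC(=O)c1cc2cc(-c3cnc(OC)c(NS(=O)(=O)c4ccc(F)cc4)c3)ccc2[nH]1`, on another core again, reaches only the limit > 20000 nM in this assay. Compound 4 `CCOC(=O)c1cnc2ccc(-c3cnc(OC)c(NS(=O)(=O)c4ccc(F)cc4)c3)cn12` keeps the core of compound 1 and differs by 4-fluorophenyl in place of methyl on a sulfonyl sulfur. Among the compounds with values here, with no measured step of this kind on the shared core, compound 4 is expected to stay close to compound 1, at an estimated 180 nM (range 40 nM to 800 nM) in this assay. The expected step is a 1.3-fold lower number from compound 1 to compound 4 (0.11 log units; within the scatter), small and within the scatter.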

Compound 4, half-maximal inhibitory concentration: 510 nM
The estimate for compound 4 lay 2.8-fold (0.45 log units) below the measured number; the range from low to high includes it.
By their numbers in this assay, from the lowest: compound 1; then compounds 2 and 4 (each within the scatter of the next). At a limit, above all of these: compound 3.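

On the shared core, the sulfonyl sulfur tolerates 4-fluorophenyl in place of methyl at a modest cost: in this assay the change gives a 2.2-fold higher number from compound 1 to compound 4 (0.35 log units; beyond the scatter). This single matched pair shows that a six-membered aromatic ring at this place lowers the read-out's strength only modestly and does not abolish activity. Nothing measured here gives a reason for the step.

Open, as far as these compounds go, is whether plain phenyl on the sulfonyl sulfur would read like compound 4 or compound 1. Also open, from the compounds shown here alone, is how an ethyl or longer chain, or a dimethylamino group, would read at this place.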